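The source may hold more compounds than are shown below. What is called first, only, known or untested is meant among the compounds shown, and "the series" means these compounds.

Compound 1, `CNC(=O)c1cc(OC)n(-c2ccccc2)n1`, in a functional assay on the whole organism (strain Wistar) for inhibition, with Rattus norvegicus as the target, read by paw edema, with stated times of 30 min and 3 h, at a dose of 100 mg/kg by the oral route (a lower number here means less inhibition, a higher number more inhibition at the dose given (going by the name of the read-out)), gives 57.9%.
Compound 2, `CCCOc1cc(C(=O)N(C)C)nn1-c1ccccc1`, in this assay gives 26.2%.
Compound 3, `CCCCOc1cc(C(=O)NCCC)nn1-c1ccccc1`, in this assay gives 51.2%.

Among these three, compound 2 stands lowest. Compound 3 sits above it by a margin that goes beyond the usual scatter, and compound 1 sits higher still, also beyond the scatter. Compound 3 carries a longer chain on the ring oxygen than compound 2 together with a different amide, so no single change between the measured compounds can be isolated; the pair only shows that the two values lie apart.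

Compound 4, `CC(C)CCOc1cc(C(=O)N(C)C)nn1-c1ccccc1`, has not yet been tested. It differs from compound 2 in one place: isopropyl in place of methyl on a saturated chain carbon, two bonds along the chain from an oxygen on an aromatic ring. Going by the values given here, nothing among the measured compounds tracks this particular change on its own, so any expectation rests on the general spread of the three values. A rise from compound 2 to compound 4 in this assay of a number 9.8 percentage points higher from compound 2 to compound 4 (within the scatter) is expected, though it may well stay within the scatter. Compound 4 is accordingly estimated to give 36%, with a likely range from 16% to 56%.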

Compound 4, a percentage reported as inhibition, in the whole organism at one dose (the size of the read-out at that dose, not a potency): 25.3%
For compound 4 the middle estimate is 10.7 percentage points above the measured one; measured number inside the range.
By their numbers in this assay, from the lowest: compounds 4 and 2 (each within the scatter of the next); then compounds 3 and 1 (each within the scatter of the next).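

Going by these compounds alone, the exchange of methyl for isopropyl on a saturated chain carbon, two bonds along the chain from an oxygen on an aromatic ring, gives the first comparison here in which only one place changes, and in this assay it reads a number 0.9 percentage points lower from compound 2 to compound 4 (within the scatter) with the rest of the structure held fixed. For this pair, then, going from the propoxy chain to the isopentyloxy chain on the shared core, with the amide of compound 2 kept, leaves no difference that can be told from the usual scatter at the dose given. No evidence here speaks to how this result comes about.

The values of compound 1 and compound 3 stand apart from that of compound 2, but each differs from it in more than one place, and so the compounds shown cannot tell whether the chain on the ring oxygen or the amide accounts for that gap. Also open, on these data alone, is whether the same exchange would read alike with the amide of compound 3 in place, or how an amine or a carboxylic acid at the end of the chain would read.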